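A few compounds are considered here, and "the series" means these few. Any claim that something is new, unique, unknown or untested is made for them only; others in the source may bear on it.

Measured compounds:
- Compound 1, `O=C(CN1CCN(c2ccccc2)CC1)N(c1ccccc1)c1ccccc1`, gives 50 mg/kg in a toxicity assay on the whole organism (strain albino) for activation, with Mus musculus as the target, with stated times of 30 min and 240 min; on this read-out lower numbers stand for an effect already at smaller amounts and higher numbers for an effect only at larger amounts of compound.
- Compound 2, `O=C(CN1CCN(c2cccc(C(F)(F)F)c2)CC1)N(c1ccccc1)c1ccccc1`, gives 48 mg/kg in this assay.
- Compound 3, `COc1ccccc1N1CCN(CC(=O)N(c2ccccc2)c2ccccc2)CC1`, gives 50.4 mg/kg in this assay.

All three numbers sit close together, and the three steps between them, a 1.0-fold lower number from compound 1 to compound 2 (0.02 log units; within the scatter), a 1.0-fold higher number from compound 1 to compound 3 (0.00 log units; within the scatter) and a 1.1-fold higher number from compound 2 to compound 3 (0.02 log units; within the scatter), each stay within the scatter of repeated measurements. Compound 3 therefore cannot be set apart from compound 1 or compound 2 on these numbers; its value is one of three that are, for practical purposes, the same.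

Compound 4, `O=C(CN1CCN(c2ccc(Cl)c(Cl)c2)CC1)N(c1ccccc1)c1ccccc1`, has not yet been measured in this assay. Its difference from compound 3 is 3,4-dichlorophenyl in place of 2-methoxyphenyl on an amine nitrogen in a ring. The closest parallel among the measured steps is the swap of one aryl group for another on the same ring nitrogen, a 1.1-fold higher number from compound 2 to compound 3 (0.02 log units; within the scatter), and the two single-substituent steps from compound 1 point the same way. Each of these changes to the aryl group left the number essentially unchanged. The expected step of a 1.0-fold lower number from compound 3 to compound 4 (0.00 log units; within the scatter) is therefore no change beyond the scatter. Compound 4 is estimated at 50 mg/kg, with a range from 30 mg/kg to 85 mg/kg.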

Compound 4, dose for half-maximal effect: 45 mg/kg
Beside the measured number, compound 4's estimate is 1.1-fold (0.05 log units) above it; measured number inside the range.
By their numbers in this assay, from the lowest: compounds 4, 2, 1 and 3 (each within the scatter of the next).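

In this assay, going by these compounds alone, the aryl group on the amine nitrogen in a ring now carries chlorine for the first time, and the step of a 1.1-fold lower number from compound 3 to compound 4 (0.05 log units; within the scatter) and the step of a 1.1-fold lower number from compound 2 to compound 4 (0.03 log units; within the scatter) and the step of a 1.1-fold lower number from compound 1 to compound 4 (0.05 log units; within the scatter) all stay within the scatter. The earlier compounds shown here had at most one substituent on this aryl group, so compound 4 extends the picture: at this position, 3,4-dichlorophenyl cannot be told apart from phenyl, 2-methoxyphenyl or 3-(trifluoromethyl)phenyl, and none of the four compounds goes against this flat result. No supporting measurement is available that could explain this flat result.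

On these data alone, all four compounds keep an aryl group on this nitrogen, so it remains open whether the number would also hold with a cyclohexyl or benzyl group there, or with an amine or a carboxylic acid on the aryl ring. The rest of the core of compound 1 is the same throughout, which leaves open what a change there, such as a longer chain in the linking part, would do to the number.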